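Extending the Urea Terminus from Compound 2 to Compound 4

This account rests on a few compounds, and the source may have more. Where it says the series, first, only, none or still open, it means among the compounds named here.

Of the compounds shown here, three sharing one core have been measured in a functional assay on HEK293 cells for agonist activity at Vasopressin V2 receptor (Homo sapiens), read by a luciferase reporter and cAMP accumulation; a lower number here means that less compound is needed, a higher number that more compound is needed for the effect. Compound 1 `Cc1cc(C(=O)N2CCCCc3ccccc32)cc(C)c1CNC(=O)Nc1c(F)cccc1F` gives 82 nM, compound 2 `Cc1cc(C(=O)N2CCCCc3ccccc32)ccc1CNC(=O)NCC(N)=O` gives 210 nM, and compound 3 `Cc1cc(C(=O)N2CCCCc3ccccc32)ccc1CNC(=O)N1CCC[C@@H]1C(=O)N(C)C` gives 380 nM. Compound 2 stands second highest of the three numbers; its nearest neighbour is compound 3, while its furthest is compound 1, whose lower number lies beyond the scatter.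

For the measured compounds named here, the unmeasured compound 4 `CO[C@@H]1C[C@@H](C(=O)N(C)C)N(C(=O)NCc2ccc(C(=O)N3CCCCc4ccccc43)cc2C)C1` differs from compound 2 in one place: 2-(dimethylcarbamoyl)-4-methoxypyrrolidin-1-yl in place of (carbamoylmethyl)amino on a carbonyl carbon The only measured step that bears on this change is a 1.8-fold higher number from compound 2 to compound 3 (0.26 log units; within the scatter), which placed the same ring-bearing group on the same carbonyl carbon, lacking only the methoxy group, and stayed within the scatter. Going by the values given here, no measured step addresses the methoxy group itself, so nothing beyond the scatter is expected from it. Because compound 3 gave 380 nM, compound 4 is expected to land nearby, at an estimated 350 nM with a range from 150 nM to 800 nM. This estimate means an expected step of a 1.7-fold higher number from compound 2 to compound 4 (0.22 log units; within the scatter), not clearly beyond the scatter.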

Compound 4, half-maximal effective concentration: 4.7 nM
Compound 4: the middle estimate sits 74-fold (1.87 log units) above what was measured, and the stated range ends above it.
By their numbers in this assay, from the lowest: compound 4; then compound 1; then compounds 2 and 3 (each within the scatter of the next).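

In this assay, for the compounds shown here, the substituent on the ring at this carbonyl carbon turns out to matter far more than the earlier compounds showed. Adding the methoxy group alone gives an 81-fold lower number from compound 3 to compound 4 (1.91 log units; beyond the scatter) and the full replacement of (carbamoylmethyl)amino gives a 45-fold lower number from compound 2 to compound 4 (1.65 log units; beyond the scatter), whereas the ring without the methoxy group had given only a 1.8-fold higher number from compound 2 to compound 3 (0.26 log units; within the scatter) and stayed within the scatter. Nothing available here explains why this one group has so large an effect.

On these data alone, it remains open whether the effect is specific to the methoxy group or would also appear with a hydroxy group, a fluorine atom or an ethoxy group at that ring carbon. Also open, as far as these compounds go, are the outcome with the opposite configuration at the methoxy-bearing carbon and whether the 2-(dimethylcarbamoyl) group is needed alongside the methoxy group.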